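The compounds below may be only part of what the source reports. "The series", "measured", "known", "first", "only" and "open" are said of these compounds alone.

Working notes on the thiourea series.

Compound 1 `COC(=O)c1c(NC(=S)Nc2ccc(C)cc2)sc2c1CCCC2` in an assay on HEK-Blue hTLR2 cells for agonist activity at Toll-like receptor 2 (Homo sapiens), with a stated time of 24 h (on this read-out lower numbers stand for an effect already at smaller amounts and higher numbers for an effect only at larger amounts of compound), gives 10300 nM. Compound 2 `COC(=O)c1c(NC(=S)Nc2ccc(C(F)(F)F)cc2)sc2c1CCCC2` in this assay gives 33900 nM. Within the data shown here, the only measured step, a 3.3-fold higher number from compound 1 to compound 2 (0.52 log units; beyond the scatter), is a modest one and lies beyond the scatter. On the two numbers shown, compound 2 stands highest, with compound 1 as its nearest neighbour at a lower number.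

Compound 3 `CCOC(=O)c1c(NC(=S)Nc2ccc(C(F)(F)F)cc2)sc2c1CCCC2` differs from compound 2 by methyl in place of hydrogen on a saturated chain carbon bound to an oxygen next to a carbonyl group. Among the measured compounds shown here, no measured step touches the ester part of the shared core, so nothing here shows how such a change moves the number; the one step that is known concerns a substituent on the aromatic ring and does not bear on it. The expectation is therefore a step of a 1.1-fold lower number from compound 2 to compound 3 (0.03 log units; within the scatter) in this assay, which is no step beyond the scatter. Compound 3 is estimated at 32000 nM in this assay, with a range from 12000 nM to 85000 nM.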

Compound 3, half-maximal effective concentration: 11900 nM
For compound 3 the middle estimate is 2.7-fold (0.43 log units) above the measured one; the whole stated range lies above it.
By their numbers in this assay, from the lowest: compounds 1 and 3 (each within the scatter of the next); then compound 2.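

Among these compounds, the ester part of the shared core does affect the number in this assay: with trifluoromethyl held on the aromatic ring, methoxycarbonyl to ethoxycarbonyl gives a 2.8-fold lower number from compound 2 to compound 3 (0.45 log units; beyond the scatter) as the first measured step at this position. This modest step beyond the scatter runs in the opposite direction to a 3.3-fold higher number from compound 1 to compound 2 (0.52 log units; beyond the scatter) on the aromatic ring, so the series now has measured changes in two places that move the number in opposite directions. No measurement shown gives a reason for the ester step.

As far as these compounds go, whether methoxycarbonyl to ethoxycarbonyl gives a similar step with methyl on the aromatic ring remains open, as this change is read only with trifluoromethyl. Also open, from the compounds shown here alone, is how the number moves with a longer chain on the ester oxygen, such as propyl or butyl, or with a carboxylic acid in place of the ester.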